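The source may report more compounds than this note shows. Statements on the series, on what has been measured and on what is new or still open speak of the compounds shown alone.

Two compounds of this series have been examined in a functional assay on NCI-H322M cells (Homo sapiens) for inhibition, read by sulforhodamine B assay, with a stated time of 48 h; on this read-out higher numbers stand for weaker inhibition of growth and lower numbers for stronger inhibition of growth. Compound 1 `COc1cc(-c2cc(/C=C/C(=O)c3ccc(N)cc3)[nH]n2)cc(OC)c1OC` gives 2230 nM in this assay, and compound 2 `COc1ccc(C(=O)/C=C/c2cc(-c3cc(OC)c(OC)c(OC)c3)n[nH]2)cc1OC` gives 1520 nM. The two differ at a carbonyl carbon, where compound 2 carries 3,4-dimethoxyphenyl in place of 4-aminophenyl, and the step of a 1.5-fold lower number from compound 1 to compound 2 (0.17 log units; within the scatter) is the only one measured so far, so compound 2 stands at a number that is not separated from compound 1 beyond the scatter. Compound 3 `COc1cc(-c2cc(/C=C/C(=O)c3ccc(F)c(F)c3)[nH]n2)cc(OC)c1OC` has not yet been measured. Its change from compound 2 is 3,4-difluorophenyl in place of 3,4-dimethoxyphenyl on a carbonyl carbon. Going by the values given here, the one measured step bears on it only loosely, since it concerns the same carbonyl carbon but a different pair of groups, and it was small. A step beyond the scatter is therefore not expected. The estimated step is a 1.3-fold higher number from compound 2 to compound 3 (0.12 log units; within the scatter). Compound 3 is expected to give about 2000 nM in this assay, within a range from 700 nM to 6000 nM.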

Compound 3, concentration for 50% growth inhibition: 3370 nM
Estimate against measurement, compound 3: 1.7-fold (0.23 log units) below; the measured number falls inside the stated range.
By their numbers in this assay, from the lowest: compounds 2, 1 and 3 (each within the scatter of the next, the first and the last beyond it).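

Going by these compounds alone, at the carbonyl carbon, this assay now gives a first step beyond the scatter: 3,4-difluorophenyl in place of 3,4-dimethoxyphenyl yields a 2.2-fold higher number from compound 2 to compound 3 (0.35 log units; beyond the scatter), a modest loss of growth inhibition. The same group in place of 4-aminophenyl yields a 1.5-fold higher number from compound 1 to compound 3 (0.18 log units; within the scatter), so 3,4-difluorophenyl and 4-aminophenyl cannot be told apart here, and the position separates only the two ends of this small set, compound 2 and compound 3. Nothing given here accounts for the step at this position.

From the compounds shown here alone, how plain phenyl or 4-methoxyphenyl would compare with these three groups remains open. So does whether this carbonyl carbon would accept something other than a substituted phenyl ring, such as a carboxylic acid-bearing chain or a simple alkyl chain.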